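Cytotoxicity of Diarylpyrimidines with Varied Aryl Substituents

The source may hold more compounds than are shown below. What is called first, only, known or untested is meant among the compounds shown, and "the series" means these compounds.

Compound 1 `Cc1cc(C#N)cc(C)c1Oc1nc(Nc2ccc(C#N)cc2)ncc1-c1ccccc1`: 31800 nM
Compound 2 `Cc1cc(C#N)cc(C)c1Oc1nc(Nc2ccc(C#N)cc2)ncc1-c1ccoc1`: 4980 nM
Compound 3 `Cc1cc(C#N)cc(C)c1Oc1nc(Nc2ccc(C#N)cc2)ncc1-c1cccc2ccccc12`: > 267000 nM

Three compounds sharing one core were tested in an ADME assay on MT4 cells (Homo sapiens) for cytotoxicity, read by MTT assay, with a stated time of 5 days; on this read-out lower numbers stand for higher toxicity in this test and higher numbers for lower toxicity in this test. Compound 1 gives 31800 nM and compound 2 gives 4980 nM. For compound 3 only a limit of the assay is known, > 267000 nM, so the numbers place it at the top of this set without fixing it; this is the limit of > 267000 nM in this assay, at which 1 of the 3 values shown sits.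

The change from compound 3 to compound 4 `Cc1cc(C#N)cc(C)c1Oc1nc(Nc2ccc(C#N)cc2)ncc1-c1cccnc1` is pyridin-3-yl in place of naphthalen-1-yl on an aromatic carbon. Within the data shown here, two measured steps bear on this change. The step of an at least 8.3-fold higher number from compound 1 to compound 3 (0.92 log units; beyond the scatter) and the step of an at least 53-fold higher number from compound 2 to compound 3 (1.72 log units; beyond the scatter) both show that putting naphthalen-1-yl in this place raised the number well beyond the scatter. Compound 4 removes that group and brings in a single six-membered ring, as in compound 1, so a reversal of the earlier step is expected, with a lower number from compound 3 to compound 4, estimated as an at least 8.9-fold lower number from compound 3 to compound 4 (0.94 log units; beyond the scatter). Compound 4 is therefore estimated at 30000 nM, within a range from 6000 nM to 150000 nM.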

Compound 4, half-maximal cytotoxic concentration: 13500 nM
The estimate for compound 4 lay 2.2-fold (0.35 log units) above the measured number; the measured number falls inside the stated range.
By their numbers in this assay, from the lowest: compound 2; then compound 4; then compound 1. At a limit, above all of these: compound 3.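

Pyridin-3-yl does not keep the high number seen with naphthalen-1-yl in this assay: the change gives an at least 19-fold lower number from compound 3 to compound 4 (1.29 log units; beyond the scatter). Among the single-ring groups, the ring nitrogen of pyridin-3-yl also separates it from phenyl, with a 2.4-fold lower number from compound 1 to compound 4 (0.37 log units; beyond the scatter), while furan-3-yl still gives the lowest number, with a 2.7-fold higher number from compound 2 to compound 4 (0.43 log units; beyond the scatter); this position therefore responds to the make-up of a single ring, not only to the change from two rings to one. Compound 3 stands at a limit and not at a number, so the first step gives only a bound: the limit of > 267000 nM in this assay, at which 1 of the 4 values shown sits.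

From the compounds shown here alone, how far the number of compound 3 lies beyond that limit remains open. So does whether a thiophen-3-yl group, a pyridin-4-yl group or an amine at this place would fall within the span of the single-ring compounds.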